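An Oxadiazole Replaces a Triazole on the Shared Core

A few compounds are considered here, and "the series" means these few. Any claim that something is new, unique, unknown or untested is made for them only; others in the source may bear on it.

Two compounds built on one urea core have been examined in a functional assay on a cell-free system (plasma) with sterol O-acyltransferase, Soat (Rattus norvegicus) as the target; a lower number here means that less compound is needed, a higher number that more compound is needed for the effect. Compound 1 `Cc1cc(C)c(NC(=O)N(Cc2ccc(-c3ccccc3)s2)C2CCCCCC2)c(C)c1` is one of them. In this assay compound 1 gives < 1 mg/kg, which is a limit of the assay rather than a number (the limit of < 1 mg/kg in this assay, at which 1 of the 2 values shown sits). Compound 2 `Cc1cc(C)c(NC(=O)N(Cc2ccc(-c3n[nH]c(C)n3)cc2)C2CCCCCC2)c(C)c1` is the other. In this assay compound 2 gives > 1 mg/kg, again a limit of the assay and not a number (the limit of > 1 mg/kg in this assay, at which 1 of the 2 values shown sits). The two values therefore sit on opposite sides of one threshold, and compound 2 stands on the side where more compound is needed. Compound 3 `Cc1cc(C)c(NC(=O)N(Cc2ccc(-c3nnc(C)o3)cc2)C2CCCCCC2)c(C)c1` differs from compound 2 in one place: 5-methyl-1,3,4-oxadiazol-2-yl in place of 5-methyl-1H-1,2,4-triazol-3-yl on an aromatic carbon. For the measured compounds named here, no measured step covers such a change. The step that the limit leaves unreadable from compound 2 to compound 3 is expected to stay within the scatter. Compound 3 is estimated at about 2 mg/kg, between 0.6 mg/kg and 7 mg/kg.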

Compound 3, dose for half-maximal effect: > 0.32 mg/kg
Compound 3: a limit, no number (the forecaster's own chance of this, stated with the estimate: 50%); the middle value lies beyond the limit too.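

Compound 2 and compound 3 both stand only as limits in this assay, so the step between them cannot be read. The compounds shown leave open whether 5-methyl-1,3,4-oxadiazol-2-yl in place of 5-methyl-1H-1,2,4-triazol-3-yl changes the dose needed, and by how much.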